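The source may hold more compounds than are shown below. What is called first, only, known or untested is meant among the compounds shown, and "the series" means these compounds.

Compound 1, `COCOc1ccc(C(=O)/C=C/c2ccc(OC)c(CC=C(C)C)c2)c(O)c1`, was tested in an assay on isolated protein for inhibition of Aromatase (Homo sapiens); a lower number here means a stronger inhibitor, a higher number a weaker inhibitor. For compound 1 the outcome is recorded only as a limit of the assay, > 261000 nM. That limit is also the point described by the limit of > 261000 nM in this assay, at which 1 of the 2 values shown sits. Compound 2, `COCOc1ccc2c(c1)OC(c1ccc(OCOC)c(CC=C(C)C)c1)CC2=O`, is the second compound of the pair, and in this assay compound 2 gives 14000 nM. Among the measured compounds shown here, of the two values shown, that of compound 2 is the only real number; the other is a limit, so compound 2 is the sole fixed reference point available.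

Compound 3, `COCOc1ccc2c(c1)OC(c1ccc(OC)c(CC=C(C)C)c1)CC2=O`, has not yet been measured. It differs from compound 2 in one place: hydrogen in place of methoxy on a saturated chain carbon bound to an oxygen on an aromatic ring. For the measured compounds named here, no measured pair here shows this same change, so there is no direct guide to its effect. Since only a small methoxy is lost, the expected step is no change at the digits printed from compound 2 to compound 3 (within the scatter), which means no movement beyond the usual scatter in either direction. Compound 3 is therefore estimated to give 14000 nM in this assay, with a likely range from 5000 nM to 40000 nM.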

Compound 3, half-maximal inhibitory concentration: 7670 nM
Compound 3: middle estimate off by 1.8-fold (0.26 log units), on the high side; the measured number falls inside the stated range.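

Among the compounds shown here, replacing methoxymethoxy with methoxy gives a 1.8-fold lower number from compound 2 to compound 3 (0.26 log units; within the scatter) in this assay, and this is the first direct reading of a single structural change in this set. A step of this size cannot be told apart from the differences seen between repeated measurements, so this assay detects no effect of removing the methoxy from the saturated chain carbon bound to an oxygen on an aromatic ring. Nothing shown here offers an explanation for this result.

The compounds shown test only two groups at this place, methoxymethoxy and methoxy, so it remains open whether a much longer chain, an amine or a carboxylic acid would be tolerated equally well. It is also unknown whether the same shortening of the remaining methoxymethoxy group on the shared core would leave the number within the usual scatter, or whether that second place responds differently.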